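Bromo for Ethyl on the Core: Expected Cytotoxicity

This account rests on a few compounds, and the source may have more. Where it says the series, first, only, none or still open, it means among the compounds named here.

Compound 1 `CCc1ccc2[nH]c(=O)c(CN(Cc3ccc(C(C)(C)C)cc3)C(C)c3ccc(F)cc3)cc2c1` gives 2800 nM in a toxicity assay on MDCK cells (Canis lupus familiaris) for cytotoxicity, read by crystal violet staining, with a stated time of 48 h; on this read-out higher numbers stand for lower toxicity in this test and lower numbers for higher toxicity in this test.
Compound 2 `CCc1ccc2[nH]c(=O)c(CN(Cc3ccc(C(C)(C)C)cc3)C(C)c3ccc(OC)c(Cl)c3)cc2c1` gives only the assay limit of > 10000 nM in this assay.

Compound 2 thus stands at the upper edge of what this assay reports, with no exact number. Going by the values given here, the one measured step, an at least 3.5-fold higher number from compound 1 to compound 2 (0.55 log units; beyond the scatter), is at least modest, and its size is bounded by the limit of > 10000 nM in this assay, at which 1 of the 2 values shown sits.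

Compound 3 `COc1ccc(C(C)N(Cc2ccc(C(C)(C)C)cc2)Cc2cc3cc(Br)ccc3[nH]c2=O)cc1Cl` differs from compound 2 by bromo in place of ethyl on an aromatic carbon. No measured step touches this part of the shared core; the only step shown concerns a different group. There is therefore no basis for expecting a change beyond the scatter in this assay from this exchange, and the estimate for compound 3 is a step that the limit leaves unreadable from compound 2 to compound 3, resting on the limit that compound 2 gives.

Compound 3 is therefore expected near 12000 nM, within a range from 4000 nM to 40000 nM.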

Compound 3, half-maximal cytotoxic concentration: > 10000 nM
Compound 3: a limit, no number; the forecaster's own chance of this, stated with the estimate: 60%; the middle value does not contradict the limit.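

No step can be read from compound 2 to compound 3, because each gives a limit and not a number: the limit of > 10000 nM in this assay, at which 2 of the 3 values shown sit. The compounds shown leave open whether bromo in place of ethyl changes the toxicity seen in this assay at all.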